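The compounds below may be only part of what the source reports. "The series", "measured", "known", "first", "only" and "open" are said of these compounds alone.

Series notes. Compound 1 `CS/C(=N\C(=O)c1cc2ccccc2s1)NC(=O)c1cc2ccccc2s1` and compound 2 `CS/C(=N\C(=O)c1ccco1)NC(=O)c1ccco1` carry the same methylsulfanyl group on different cores; the difference between the two cores is not broken down here. In a functional assay on PC-3 cells (Homo sapiens) for cytotoxicity, read by MTT assay, with a stated time of 72 h (a lower number here means a stronger inhibitor of growth, a higher number a weaker inhibitor of growth), compound 1 gives 39400 nM. For compound 2 the assay reports only a limit, > 100000 nM. Compound 3 `O=C(/N=C(/NC(=O)c1ccco1)[Se]Cc1ccccc1)c1ccco1` differs from compound 2 by a group of 8 heavy atoms (7 carbon, 1 selenium; one six-membered aromatic ring of carbon only) in place of a group of 2 heavy atoms (1 carbon, 1 sulfur; no ring), on a carbon with a double bond to nitrogen. In this assay compound 3 gives 57600 nM, which is an at least 1.7-fold lower number from compound 2 to compound 3 (0.23 log units; that floor lies within the scatter), read against (the limit of > 100000 nM in this assay, at which 1 of the 3 values shown sits). Compound 4 `O=C(/N=C(/NC(=O)c1cc2ccccc2s1)[Se]Cc1ccccc1)c1cc2ccccc2s1` is not yet measured; it differs from compound 1 by a group of 8 heavy atoms (7 carbon, 1 selenium; one six-membered aromatic ring of carbon only) in place of a group of 2 heavy atoms (1 carbon, 1 sulfur; no ring), on a carbon with a double bond to nitrogen, the same change at the same place. The expected step is a 1.3-fold lower number from compound 1 to compound 4 (0.12 log units; within the scatter), resting on an at least 1.7-fold lower number from compound 2 to compound 3 (0.23 log units; that floor lies within the scatter) whose floor lies within the scatter, so little movement is assumed. Compound 4 is estimated at 30000 nM, with a range from 12000 nM to 75000 nM.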

Compound 4, concentration for total growth inhibition: 58400 nM
Beside the measured number, compound 4's estimate is 1.9-fold (0.29 log units) below it, and the stated range covers the measured number.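

On the core of compound 1, putting the selenium-carrying aromatic group in place of methylsulfanyl gives a 1.5-fold higher number from compound 1 to compound 4 (0.17 log units; within the scatter) in this assay, so this core shows no movement beyond the scatter. This neither shows that the change carries over from one core to the other nor shows that it fails to, and the two steps cannot be separated: the same change on two cores in this assay, an at least 1.7-fold lower number (0.23 log units; that floor lies within the scatter) from compound 2 to compound 3 and a 1.5-fold higher number (0.17 log units; within the scatter) from compound 1 to compound 4; the limit leaves it open whether they differ. The step on the core of compound 2 has only a floor, as compound 2 stands at an assay limit: the limit of > 100000 nM in this assay, at which 1 of the 4 values shown sits.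

The compounds shown leave open whether the selenium or the aromatic ring contributes to either step. Also open, as far as these compounds go, is how a methyl group on selenium, or an amine or carboxylic acid on that ring, would read in this assay.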